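Changing the aryl group on the ring amine nitrogen

The source may report more compounds than this note shows. Statements on the series, on what has been measured and on what is new or still open speak of the compounds shown alone.

Measured compounds in a functional assay on HL-60 cells (Homo sapiens) for inhibition, read by MTT assay, with a stated time of 72 h; on this read-out higher numbers stand for weaker inhibition and lower numbers for stronger inhibition:
- compound 1 `Cc1nc(-c2ccccc2)c(C(=O)N2CCN(c3cccc(C(N)=O)c3)CC2)o1`: 71 nM
- compound 2 `Cc1nc(-c2ccccc2)c(C(=O)N2CCN(c3ccc(F)cc3)CC2)o1`: a limit, > 1000 nM
- compound 3 `Cc1nc(-c2ccccc2)c(C(=O)N2CCN(c3ccccc3C(F)(F)F)CC2)o1`: 120 nM

Three compounds share one core and differ only in the aryl group on an amine nitrogen in a ring. Compound 3 shows the highest of the two real numbers, but compound 1 lies nearest, with a 1.7-fold higher number from compound 1 to compound 3 (0.23 log units; within the scatter). Compound 2 gives only a limit of this assay, (the limit of > 1000 nM in this assay, at which 1 of the 3 values shown sits). The step of an at least 8.3-fold lower number from compound 2 to compound 3 (0.92 log units; beyond the scatter) is therefore the one clear move among the three.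

Compound 4 `COc1cc(OC)cc(N2CCN(C(=O)c3oc(C)nc3-c3ccccc3)CC2)c1` is not yet measured. Its change from compound 3 is 3,5-dimethoxyphenyl in place of 2-(trifluoromethyl)phenyl on an amine nitrogen in a ring. Both measured steps act at this same place, yet neither involves a 3,5-dimethoxyphenyl, so they set only a wide frame: a change here can be small, as a 1.7-fold higher number from compound 1 to compound 3 (0.23 log units; within the scatter), or large, as an at least 14-fold higher number from compound 1 to compound 2 (1.14 log units; beyond the scatter). Compound 4 is therefore expected to land close to compound 3, with a step of a 1.7-fold higher number from compound 3 to compound 4 (0.22 log units; within the scatter) that may fall within the scatter. The estimate for compound 4 in this assay is 200 nM, within a range of 50 nM to 1200 nM.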

Compound 4, half-maximal inhibitory concentration: 19.2 nM
Beside the measured number, compound 4's estimate is 10-fold (1.02 log units) above it; measured number below the stated range.
By their numbers in this assay, from the lowest: compound 4; then compounds 1 and 3 (each within the scatter of the next). At a limit, above all of these: compound 2.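

In this assay, 3,5-dimethoxyphenyl is the only aryl group shown that clearly lowers the number below those of both other measured compounds: a 6.3-fold lower number from compound 3 to compound 4 (0.80 log units; beyond the scatter) and a 3.7-fold lower number from compound 1 to compound 4 (0.57 log units; beyond the scatter). The earlier values showed 3-carbamoylphenyl and 2-(trifluoromethyl)phenyl within the scatter of each other, whereas this result shows that this position can still give a clear gain, even though the leaving and entering groups both have 10 heavy atoms. Compound 2 stands at a limit, so an at least 52-fold lower number from compound 2 to compound 4 (1.71 log units; beyond the scatter) gives a bound rather than an exact gap: the limit of > 1000 nM in this assay, at which 1 of the 4 values shown sits.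

These compounds cannot show whether both methoxy groups are needed, since no phenyl group with a single methoxy group is included. From the compounds shown here alone, it also remains open whether ethoxy or hydroxyl groups in their place would keep the number this low.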